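Butyl in Place of Isopropyl on the Shared Core

The compounds below may be only part of what the source reports. "The series", "measured", "known", "first", "only" and "open" are said of these compounds alone.

Measured so far in a functional assay on HCT-116 cells (Homo sapiens) for antiproliferative activity, read by CCK-8 assay, with a stated time of 72 h, tested at 8 uM; a lower number here means a weaker effect, a higher number a stronger effect of the compound at the concentration tested:
compound 1, `CC(C)n1cnc2c(Nc3cccc(Cl)c3)nc(NCOCc3ccc(C(=O)Nc4ccccc4N)cc3)nc21`, gives 63.4%
compound 2, `Nc1ccccc1NC(=O)/C=C/c1ccc(Cn2cnc3c(NC4CCCCC4)nc(Cl)nc32)cc1`, gives 18.7%
compound 3, `CC(C)n1cnc2c(Nc3ccccc3)nc(NCOCc3ccc(C(=O)Nc4ccccc4N)cc3)nc21`, gives 18.8%

Compound 1 stands highest of the three numbers, and both steps from it to the others lie beyond the scatter. The nearest measured compound is compound 3, which differs from compound 1 in one place only: hydrogen in place of chloro on an aromatic carbon. That single change gave a number 44.6 percentage points lower from compound 1 to compound 3 (beyond the scatter), a large loss. Compound 2 differs in more than one place, so its value shows only that it sits far below compound 1.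

Compound 4, `CCCCn1cnc2c(Nc3cccc(Cl)c3)nc(NCOCc3ccc(C(=O)Nc4ccccc4N)cc3)nc21`, keeps the chloro of compound 1 and alters a different part of the shared core: butyl in place of isopropyl on an aromatic nitrogen. Among the measured compounds shown here, no measured step concerns this part of the molecule, so there is nothing to draw on except that the chloro, which mattered so much between compound 1 and compound 3, is retained. The change from compound 1 to compound 4 is therefore expected to give a step of a number 5.4 percentage points lower from compound 1 to compound 4 (within the scatter), that is, no shift beyond the scatter. Compound 4 is estimated at 58%, within a range from 35% to 75%.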

Compound 4, a percentage reported as inhibition, at one concentration (the size of the read-out at that concentration, not a potency): 71.9%
For compound 4 the middle estimate is 13.9 percentage points below the measured one, and the stated range covers the measured number.
By their numbers in this assay, from the lowest: compounds 2 and 3 (each within the scatter of the next); then compounds 1 and 4 (each within the scatter of the next).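

In this assay, the aromatic nitrogen of the five-membered ring accepts this change: putting butyl in place of isopropyl gives a number 8.5 percentage points higher from compound 1 to compound 4 (within the scatter), so the added carbon leaves no shift that can be told from the scatter. Set against a number 44.6 percentage points lower from compound 1 to compound 3 (beyond the scatter), a change in another part of the molecule, this step is small, which shows that with the chloro kept the number holds up through this one swap on the nitrogen. Nothing measured here offers an explanation for this tolerance.

Going by these compounds, it remains open whether a longer chain such as hexyl, a ring such as cyclopentyl, or a chain ending in an amine or a carboxylic acid would hold the number at this nitrogen. Also open, on these data alone, is whether butyl would do the same on the core of compound 3, which lacks the chloro.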